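The source may report more compounds than this note shows. Statements on the series, on what has been measured and on what is new or still open speak of the compounds shown alone.

Measured in a functional assay on A549 cells (Homo sapiens) for inhibition, read by MTT assay, with a stated time of 72 h; a lower number here means a stronger inhibitor, a higher number a weaker inhibitor:
- compound 1 `COc1ccccc1-c1csc2cnc(Nc3ccc(NC(=O)C4CCNCC4)cc3)nc12`: 450 nM
- compound 2 `COc1ccccc1-c1csc2cnc(Nc3ccc(NC(=O)[C@H]4CCCNC4)cc3)nc12`: 500 nM

Only these two numbers are available so far. Compound 2, at 500 nM, stands within the scatter of compound 1, at 450 nM, so neither can be ranked above the other.

The next structure is compound 3 `COc1ccccc1-c1csc2cnc(Nc3ccc(NC(=O)[C@@H]4CCCNC4)cc3)nc12`, which is set against compound 2 as follows: the two compounds have the same atoms and bonds and differ only in configuration as drawn: 1 of 1 stereo elements differ; a stereocentre at a saturated ring carbon is drawn S in compound 2 and R in compound 3. Among the compounds with values here, no measured pair tests a change of configuration. Within the data shown here, the nearest evidence is the one measured step, which places piperidin-3-yl in place of piperidin-4-yl on a carbonyl carbon: a 1.1-fold higher number from compound 1 to compound 2 (0.05 log units; within the scatter). That step stayed within the scatter, but it is a step of a different kind and says nothing direct about the stereocentre.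

In this assay, therefore, no step beyond the scatter is expected, and no direction is favoured. The range is kept wide because the evidence is so thin. The expected step is no change at the digits printed from compound 2 to compound 3 (within the scatter). The estimated value for compound 3 is 500 nM, with an expected range of 200 nM to 1300 nM.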

Compound 3, half-maximal inhibitory concentration: 410 nM
Estimate against measurement, compound 3: 1.2-fold (0.09 log units) above; low and high end bracket the measured number.
By their numbers in this assay, from the lowest: compounds 3, 1 and 2 (each within the scatter of the next).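

The stereocentre on the piperidin-3-yl ring now has a direct test in this assay, and the forms drawn S and R cannot be told apart, with a 1.2-fold lower number from compound 2 to compound 3 (0.09 log units; within the scatter). This pair isolates configuration alone, which the earlier pair could not do: the fact that compounds 2 and 3 differ only in the configuration as drawn. The form drawn R also cannot be separated from the piperidin-4-yl compound, with a 1.1-fold lower number from compound 1 to compound 3 (0.04 log units; within the scatter), so neither the ring position printed in these names nor the configuration at this carbon separates the three compounds in this assay.

The compounds shown leave open whether a methyl or an acetyl group on the ring nitrogen, or a pyrrolidine or an open aminoalkyl chain in place of the piperidine, would move the number beyond the scatter. They also leave open whether the two configurations would stay inseparable if the methoxy group on the shared core gave way to a hydroxyl group or a chlorine atom.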